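Swapping Nitro for Pentafluoroethyl on a Second Core

The compounds below may be only part of what the source reports. "The series", "measured", "known", "first", "only" and "open" are said of these compounds alone.

Compound 1 `O=C1CCCCN1[C@@H]1c2cc([N+](=O)[O-])ccc2OC(CF)(CF)[C@H]1O` and compound 2 `O=C1CCCCN1[C@@H]1c2cc(C(F)(F)C(F)(F)F)ccc2OC(CF)(CF)[C@H]1O` share one core. In a functional assay (aorta) with Rattus norvegicus as the target (a lower number here means that less compound is needed, a higher number that more compound is needed for the effect), compound 1 gives 2.75 nM and compound 2 gives 3.89 nM. The change between them is 1,1,2,2,2-pentafluoroethyl in place of nitro on an aromatic carbon and it made the step of a 1.4-fold higher number from compound 1 to compound 2 (0.15 log units; within the scatter). Compound 3 `O=C1CCCCN1C1=CC(CF)(CF)Oc2ccc([N+](=O)[O-])cc21` stands on a second core; the difference between the two cores is not broken down here. In this assay compound 3 gives 17.4 nM, the highest of the three numbers, beyond the scatter from both compound 1 and compound 2. Compound 4 `O=C1CCCCN1C1=CC(CF)(CF)Oc2ccc(C(F)(F)C(F)(F)F)cc21` has not yet been measured. It differs from compound 3 by 1,1,2,2,2-pentafluoroethyl in place of nitro on an aromatic carbon, the same change that was made from compound 1 to compound 2, at the same place. Because the earlier step of a 1.4-fold higher number from compound 1 to compound 2 (0.15 log units; within the scatter) stayed within the scatter, compound 4 is expected to make a step of about a 1.4-fold higher number from compound 3 to compound 4 (0.14 log units; within the scatter). The estimate for compound 4 in this assay is 24 nM, expected to lie between 10 nM and 55 nM.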

Compound 4, half-maximal effective concentration: 5.62 nM
The estimate for compound 4 lay 4.3-fold (0.63 log units) above the measured number, and the stated range ends above it.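

In this assay the swap of nitro for 1,1,2,2,2-pentafluoroethyl did not carry over unchanged from one core to the other, the new step being a 3.1-fold lower number from compound 3 to compound 4 (0.49 log units; beyond the scatter). The steps on the two cores differ by more than the usual scatter of such measurements: the same change on two cores in this assay, a 1.4-fold higher number (0.15 log units; within the scatter) from compound 1 to compound 2 and a 3.1-fold lower number (0.49 log units; beyond the scatter) from compound 3 to compound 4, 4.4-fold (0.64 log units) apart, beyond the scatter of two such steps. This shows that the outcome of this change in the series depends on the core that carries it, so a step read on one core cannot simply be transferred to the other, but with a single pair on each core it does not show which part of the cores is responsible, or how the change would behave on a further core.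

The compounds shown leave open whether other groups on that aromatic carbon, such as an amine, a carboxylic acid or a longer fluorinated chain, would also give different steps on the two cores. They also leave open whether the gap between the cores is particular to the exchange of nitro for 1,1,2,2,2-pentafluoroethyl.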